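The compounds below may be only part of what the source reports. "The series", "measured", "known", "first", "only" and "open" are said of these compounds alone.

In a functional assay on MDA-MB-231 cells (Homo sapiens) for inhibition, read by MTT assay, with a stated time of 5 days (a higher number here means a weaker inhibitor, a lower number a stronger inhibitor), compound 1 (`Cc1cc(Nc2nc(NCc3ccc(F)cc3F)nc3[nH]ncc23)n[nH]1`) gives 2670 nM, compound 2 (`COc1ccc(CNc2nc(Nc3cc(C)[nH]n3)c3cn[nH]c3n2)cc1`) gives 1320 nM and compound 3 (`Cc1cc(Nc2nc(NCc3ccc(Cl)cc3)nc3c2cnn3C2CCOCC2)n[nH]1`) gives 9420 nM, the highest number of the three. Compound 4 (`Cc1cc(Nc2nc(NCc3ccc(Cl)cc3)nc3c2cnn3C(C)C)n[nH]1`) differs from compound 3 in one place, isopropyl in place of oxan-4-yl on an aromatic nitrogen. Within the data shown here, the only measured single-place step, a 2.0-fold lower number from compound 1 to compound 2 (0.31 log units; beyond the scatter), is modest and lies elsewhere in the structure, so it says little about this change. Among the measured compounds shown here, no measured step covers that nitrogen, so no shift beyond the scatter is expected in this assay. The expected result is a 1.3-fold lower number from compound 3 to compound 4 (0.13 log units; within the scatter). Compound 4 is estimated at 7000 nM, with an expected range of 2800 nM to 17000 nM.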

Compound 4, half-maximal inhibitory concentration: 4860 nM
Estimate against measurement, compound 4: 1.4-fold (0.16 log units) above; low and high end bracket the measured number.
By their numbers in this assay, from the lowest: compound 2; then compounds 1, 4 and 3 (each within the scatter of the next, the first and the last beyond it).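

In this assay, among these compounds, the exchange on the aromatic nitrogen gives a 1.9-fold lower number from compound 3 to compound 4 (0.29 log units; within the scatter) and is the first reading at this position. Oxan-4-yl, with its six-membered ring and one hydrogen-bond acceptor, and isopropyl, with neither, cannot be told apart here, so neither the ring nor its oxygen is shown to matter in this assay. No evidence bears on why this is so.

The compounds shown leave open how a piperidin-4-yl group, with its ring amine, or a chain ending in a carboxylic acid would read on that nitrogen. They also leave open whether the same tolerance holds with a different group on the benzylic side of the molecule.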